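The source may report more compounds than this note shows. Statements on the series, on what has been measured and on what is new or still open speak of the compounds shown alone.

Measured compounds:
compound 1 `Cc1ccnc(/C(N)=N/NC(=S)N2CCSCC2)c1` — 75.3%
compound 2 `Cc1cccc(/C(N)=N/NC(=S)N2CCCCC2)n1` — 65.2%
compound 3 `Cc1cccc(/C(N)=N/NC(=S)N2CCCC2)n1` — 72.2%

In a functional assay on A-431 cells (Homo sapiens) for cytotoxicity, read by MTT assay, with a stated time of 72 h, tested at 30 uM (on this read-out higher numbers stand for more inhibition of growth at the one concentration tested and lower numbers for less inhibition of growth), compound 2 holds the lowest of the three numbers; compound 3 sits within the scatter of it, while compound 1 lies beyond the scatter. Among the measured compounds shown here, the only measured step between neighbours, a number 7 percentage points higher from compound 2 to compound 3 (within the scatter), concerns the group on the thiocarbonyl carbon and stays within the scatter.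

Compound 4 `N/C(=N\NC(=S)N1CCCCC1)c1ccccn1` differs from compound 2 by hydrogen in place of methyl on an aromatic carbon. For the measured compounds named here, no measured step touches this change, so nothing speaks for a shift beyond the scatter. The expectation is therefore a step of a number 0.2 percentage points lower from compound 2 to compound 4 (within the scatter), essentially none. For compound 4 the estimated value is 65%, with a range from 50% to 80%.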

Compound 4, percent growth inhibition at one concentration: 79.7%
The estimate for compound 4 lay 14.7 percentage points below the measured number; the measured number falls inside the stated range.
By their numbers in this assay, from the lowest: compounds 2, 3, 1 and 4 (each within the scatter of the next, the first and the last beyond it).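

In this assay, among the compounds shown here, hydrogen in place of methyl on an aromatic carbon next to the ring nitrogen gives a number 14.5 percentage points higher from compound 2 to compound 4 (beyond the scatter) and this is the only step between neighbours that lies beyond the scatter. This position therefore responds to the change, at least with the piperidin-1-yl group on the thiocarbonyl carbon. Nothing available explains the step.

From the compounds shown here alone, whether the same change holds with the pyrrolidin-1-yl group of compound 3 remains open. Also open, going by these compounds, is how an amine, a methoxy group or a chlorine atom at this carbon would compare with hydrogen and methyl.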